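Cytotoxicity notes: benzylsulfanyl replacing octyloxy on the shared core

A few compounds are considered here, and "the series" means these few. Any claim that something is new, unique, unknown or untested is made for them only; others in the source may bear on it.

Measured so far, in an ADME assay on MOLT-3 cells (Homo sapiens) for cytotoxicity, with a stated time of 7 days; on this read-out lower numbers stand for higher toxicity in this test and higher numbers for lower toxicity in this test:
- compound 1 `CCCCCCCCOc1nc(N)nc2c1ncn2/C=C1/CC1(CO)CO`: > 20000 nM
- compound 2 `CC(C)Nc1nc(N)nc2c1ncn2/C=C1/CC1(CO)CO`: "not determined" (no result reported)
- compound 3 `CCCNc1nc(N)nc2c1ncn2/C=C1/CC1(CO)CO`: "not determined" (no result reported)

The value for compound 1 is a limit of this assay, not a number. Compound 2 and compound 3 carry no result in this assay, so compound 1 supplies the only entry with content, and it stands at the limit of > 20000 nM in this assay, at which 1 of the 3 values shown sits. Going by the values given here, no step between measured compounds can be drawn from these three entries.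

Compound 4 `Nc1nc(SCc2ccccc2)c2ncn(/C=C3/CC3(CO)CO)c2n1` is the next entry to be measured. It differs from compound 1 in one place: benzylsulfanyl in place of octyloxy on an aromatic carbon. The benzylsulfanyl group enters where the octyloxy group leaves, on an aromatic carbon of the shared core. Among the compounds with values here, with no measured step to lean on, no size or direction beyond the scatter is expected in this assay; the working assumption is that compound 4 stays near the limit of compound 1.

Compound 4 is expected to give about 20000 nM, estimated within 8000 nM to 50000 nM. The expected step is a number no higher from compound 1 to compound 4 (the limit leaves the size open), essentially none beyond the scatter, and a limit rather than a number is the more likely outcome.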

Compound 4, half-maximal cytotoxic concentration: > 20000 nM
Compound 4 was reported as a limit; the forecaster's own chance of this, stated with the estimate: 65%; the middle value sits exactly at the limit.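

Compound 1 and compound 4 both stand as limits rather than numbers, so no step can be read between them: the limit of > 20000 nM in this assay, at which 2 of the 4 values shown sit.

The compounds shown leave open whether benzylsulfanyl and octyloxy on the shared core differ at all on this read-out.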